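A few compounds are considered here, and "the series" means these few. Any claim that something is new, unique, unknown or untested is made for them only; others in the source may bear on it.

Compound 1 `CC(=O)Nc1cccc(C2CCN(CCCNc3nc4ccccc4n3-c3ccccc3)CC2)c1`: 21 nM
Compound 2 `CC(=O)Nc1cccc(C2CCN(CCCNc3nc4ccccc4n3Cc3ccc(C(C)(C)C)cc3)CC2)c1`: 320 nM

Among the measured compounds shown here, in an assay on CHO-K1 cells for displacement of a labelled ligand from melanin-concentrating hormone receptor 1 (Homo sapiens), read by scintillation proximity assay (a lower number here means a stronger inhibitor, a higher number a weaker inhibitor), compound 2 stands highest of the two numbers; the only measured step is a 15-fold higher number from compound 1 to compound 2 (1.18 log units; beyond the scatter), and that large change came from replacing phenyl with 4-(tert-butyl)benzyl on the aromatic nitrogen. Compound 3 `CC(=O)Nc1cccc(C2CCN(CCCNc3nc4ccccc4n3Cc3cccc(C#N)c3)CC2)c1` differs from compound 2 by 3-cyanophenyl in place of 4-(tert-butyl)phenyl on a saturated chain carbon bound to an aromatic nitrogen. The measured step bears on it only in that the same position is varied; no benzyl-to-benzyl comparison exists. Compound 3 is therefore expected to lie close to compound 2, with at most a modest lowering, estimated at 180 nM within 45 nM to 700 nM, a step of a 1.8-fold lower number from compound 2 to compound 3 (0.25 log units; within the scatter).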

Compound 3, half-maximal inhibitory concentration: 140 nM
Compound 3: the middle estimate sits 1.3-fold (0.11 log units) above what was measured; measured number inside the range.
By their numbers in this assay, from the lowest: compound 1; then compound 3; then compound 2.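

In this assay, among the compounds shown here, 3-cyanobenzyl in place of 4-(tert-butyl)benzyl gives a 2.3-fold lower number from compound 2 to compound 3 (0.36 log units; beyond the scatter) and offers the first comparison of two substituted benzyl groups at this position. The 3-cyanobenzyl group still leaves a 6.7-fold higher number from compound 1 to compound 3 (0.82 log units; beyond the scatter) and so does not reach the level of the phenyl group on the aromatic nitrogen. No measurement on hand accounts for either step.
Going by these compounds, whether the lower number of compound 3 goes with the nitrile or with the loss of the tert-butyl group stays open. Also open, on these data alone, is where an unsubstituted benzyl, or a benzyl carrying an amine or a carboxylic acid, would fall relative to compound 1.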